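Second nitro on the shared core: compound 3 to compound 4

The source may report more compounds than this note shows. Statements on the series, on what has been measured and on what is new or still open speak of the compounds shown alone.

Of the compounds shown here, three carry numbers so far. In an ADME assay on RAW264.7 cells (Mus musculus) for cytotoxicity, read by MTT assay, with a stated time of 72 h, tested at 50 uM (on this read-out higher numbers stand for a stronger effect at the one concentration tested and lower numbers for a weaker effect), compound 2 `O=C(Cn1c(=O)oc2ccccc21)Nc1nc2ccccc2s1` gives 43.5%, compound 1 `O=C(Cn1c(=O)oc2cc([N+](=O)[O-])ccc21)Nc1ccccn1` gives 38.6% and compound 3 `O=C(Cn1c(=O)oc2ccccc21)Nc1nc2ccc([N+](=O)[O-])cc2s1` gives 12.4%. Compound 3 thus stands lowest of the three, its nearest neighbour being compound 1 and its furthest compound 2, both separated from it by more than the scatter.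

Compound 4 `O=C(Cn1c(=O)oc2cc([N+](=O)[O-])ccc21)Nc1nc2ccc([N+](=O)[O-])cc2s1` remains to be measured. It differs from compound 3 by nitro in place of hydrogen on an aromatic carbon; the nitro that already distinguishes compound 3 from compound 2 stays in place, so compound 4 carries two nitro groups.

Within the data shown here, only one measured step bears on this change: a number 31.1 percentage points lower from compound 2 to compound 3 (beyond the scatter), a nitro entering on a different ring. Compound 1 also carries a nitro on the shared core, but its amide partner differs from that of compound 2 and compound 3, so it offers no single-change comparison, only its own value. Among the measured compounds shown here, the one step that exists points downward, yet the number for compound 3 already leaves little room beneath it.

Compound 4 is therefore estimated at 10% (range 0% to 28%), which means an expected step of a number 2.4 percentage points lower from compound 3 to compound 4 (within the scatter) in this assay, within the scatter or slightly below.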

Compound 4, a percentage reported as inhibition, at one concentration (the size of the read-out at that concentration, not a potency): 14.8%
Beside the measured number, compound 4's estimate is 4.8 percentage points below it; the measured number falls inside the stated range.
By their numbers in this assay, from the lowest: compounds 3 and 4 (each within the scatter of the next); then compounds 1 and 2 (each within the scatter of the next).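

In this assay, nitro in place of hydrogen on an aromatic carbon of the six-membered aromatic ring of carbon only, part of a fused system of two rings, gives a number 2.4 percentage points higher from compound 3 to compound 4 (within the scatter), so with the first nitro already in place this second nitro does not separate the two compounds. The earlier nitro step, a number 31.1 percentage points lower from compound 2 to compound 3 (beyond the scatter), was beyond the scatter, but it concerned another ring and a compound without any other nitro, so that step does not carry over to this position in compound 3, and compounds 3 and 4 remain together as the lower pair of the four on this read-out. Nothing on hand gives a measured reason for this outcome.

The compounds shown leave open what this nitro does on its own, with the unsubstituted amide partner of compound 2 kept in place, since no single-change pair isolates it there. They also leave open whether an amine or a methoxy group on this aromatic carbon would behave as the nitro does, in the presence or the absence of the other nitro.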